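The source may hold more compounds than are shown below. What is called first, only, known or untested is meant among the compounds shown, and "the series" means these compounds.

Two esters of the shared core have been measured. In a functional assay on SW1573 cells (Homo sapiens) for inhibition, read by sulforhodamine B assay, with a stated time of 48 h (on this read-out lower numbers stand for stronger inhibition of growth and higher numbers for weaker inhibition of growth), compound 1 `O=C(/C=C/c1ccccc1)OCC1COCCOCCOCCOCCOCCO1` gives 48000 nM. For compound 2 `CC/C=C/CC(=O)OCC1COCCOCCOCCOCCOCCO1` this assay reports only a limit, > 100000 nM. Replacing the 2-phenylethenyl group on the carbonyl carbon by pent-2-en-1-yl thus gave an at least 2.0-fold higher number from compound 1 to compound 2 (0.31 log units; beyond the scatter), and because compound 2 sits at the limit of > 100000 nM in this assay, at which 1 of the 2 values shown sits, only the lower bound of this step is known. Compound 3 `O=C(CCCCOc1ccccc1)OCC1COCCOCCOCCOCCOCCO1` has not been measured; it differs from compound 2 by 3-phenoxypropyl in place of but-1-en-1-yl on a saturated chain carbon bound to a carbonyl carbon. For the measured compounds named here, only that one step bears on it: going from compound 1 to compound 2 removed the aromatic ring and gave an at least 2.0-fold higher number from compound 1 to compound 2 (0.31 log units; beyond the scatter), whereas compound 3 brings an aromatic ring back, now on a longer, saturated linker. A return toward the region of compound 1 is therefore expected, roughly an at least 1.6-fold lower number from compound 2 to compound 3 (0.22 log units; that floor lies within the scatter), though with wide uncertainty. Compound 3 is estimated at 60000 nM, within a range from 20000 nM to 200000 nM.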

Compound 3, concentration for 50% growth inhibition: > 100000 nM
Compound 3: a limit, no number; the forecaster's own chance of this, stated with the estimate: 40%; middle value at least 1.6-fold (0.22 log units) away from the limit.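

An aromatic ring on this chain is not enough on its own to keep the activity of compound 1: in this assay, 4-phenoxybutyl in place of 2-phenylethenyl on a carbonyl carbon gave an at least 2.0-fold higher number from compound 1 to compound 3 (0.31 log units; beyond the scatter). For the compounds shown here, whether the ring in compound 3 changes anything relative to compound 2 cannot be read, because both values are limits: the limit of > 100000 nM in this assay, at which 2 of the 3 values shown sit. Of the three esters, only compound 1 gives a real number, so 2-phenylethenyl is the only group here with a measurable effect on growth.

On these data alone, it remains open whether that activity depends on the double bond, on the length of the chain or on the absence of the phenoxy oxygen. A saturated 2-phenylethyl group would separate the first of these, and an amine on the phenyl ring would test how far the ring itself can be changed.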